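Chloro to bromo step in a halogenated series

A few compounds are considered here, and "the series" means these few. Any claim that something is new, unique, unknown or untested is made for them only; others in the source may bear on it.

Measured so far in a functional assay on LOX IMVI cells (Homo sapiens) for cytotoxicity, read by MTT assay, with a stated time of 24 h (a lower number here means a stronger inhibitor, a higher number a weaker inhibitor), for three compounds:
- compound 1 `COc1cc(-c2nc(-c3ccccc3)[nH]c2-c2ccnc(NCCCNS(=O)(=O)c3ccc(Br)cc3)n2)ccc1F` gives 33900 nM
- compound 2 `COc1cc(-c2nc(-c3ccccc3)[nH]c2-c2ccnc(NCCCNS(=O)(=O)c3ccc(Br)cc3)n2)ccc1Cl` gives 23700 nM
- compound 3 `O=S(=O)(NCCCNc1nccc(-c2[nH]c(-c3ccccc3)nc2-c2ccc(F)c(O)c2)n1)c1ccc(Cl)cc1` gives 14200 nM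

Compound 3 at 14200 nM lies within the scatter of compound 2 and lower than compound 1 by more than the scatter. The step under review leads to compound 4 `O=S(=O)(NCCCNc1nccc(-c2[nH]c(-c3ccccc3)nc2-c2ccc(F)c(O)c2)n1)c1ccc(Br)cc1` and its change is bromo in place of chloro on an aromatic carbon with bromo in place of chloro on an aromatic carbon, para to a large group.

For the measured compounds named here, no bromo-for-chloro step has been measured on this series. The nearest evidence is a different halogen exchange, a 1.4-fold lower number from compound 1 to compound 2 (0.16 log units; within the scatter) for chloro in place of fluoro on an aromatic carbon, and it stays within the scatter. The (4-bromophenyl)sulfonyl group of compound 4 also occurs in compound 2 at 23700 nM and in compound 1 at 33900 nM but both differ from compound 4 elsewhere as well, so they suggest at most a slight lean towards a higher number.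

The expected change is a 1.2-fold higher number from compound 3 to compound 4 (0.08 log units; within the scatter) and no step beyond the scatter is anticipated in this assay here. For compound 4 the estimated value is 17000 nM with an expected range from 8500 nM to 34000 nM for now.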

Compound 4, half-maximal inhibitory concentration: 5660 nM
Compound 4: middle estimate off by 3.0-fold (0.48 log units), on the high side; the measured number lies below the stated range.
By their numbers in this assay, from the lowest: compound 4; then compounds 3, 2 and 1 (each within the scatter of the next, the first and the last beyond it).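

In this assay, for the compounds shown here, the change from 4-chlorophenyl to 4-bromophenyl, para to a large group, is the first bromo-for-chloro step and lies beyond the scatter (a 2.5-fold lower number from compound 3 to compound 4 (0.40 log units; beyond the scatter)), whereas the earlier chloro-for-fluoro exchange stayed within it (a 1.4-fold lower number from compound 1 to compound 2 (0.16 log units; within the scatter)). With the (4-bromophenyl)sulfonyl group held constant, hydrogen in place of methyl on an oxygen on an aromatic ring also moves the number beyond the scatter (a 6.0-fold lower number from compound 1 to compound 4 (0.78 log units; beyond the scatter)), as does 4-fluoro-3-hydroxyphenyl in place of 4-chloro-3-methoxyphenyl (a 4.2-fold lower number from compound 2 to compound 4 (0.62 log units; beyond the scatter)), so in these two pairs the hydroxy compound has the lower number. Nothing available on these compounds accounts for the size of the bromo step.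

The compounds shown leave open whether the bromo-for-chloro step would hold on a compound carrying 4-fluoro-3-methoxyphenyl or 4-chloro-3-methoxyphenyl instead of 4-fluoro-3-hydroxyphenyl. They also leave open how iodo, an amine or a carboxylic acid would compare with bromo on this ring, and what a longer chain in the linker would do.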